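Trifluoromethyl for chloro on the benzyl ring of compound 3

The source may hold more compounds than are shown below. What is called first, only, known or untested is meant among the compounds shown, and "the series" means these compounds.

Measured so far: compound 1 `O=S(=O)(NCCCNCc1ccccc1Cl)c1cc(C(F)(F)F)cc(C(F)(F)F)c1`, 15000 nM; compound 2 `O=S(=O)(NCCCCNCc1ccc(Br)cc1)c1cc(C(F)(F)F)cc(C(F)(F)F)c1`, 2200 nM; compound 3 `O=S(=O)(NCCCNCc1ccc(Cl)c(Cl)c1)c1cc(C(F)(F)F)cc(C(F)(F)F)c1`, 2900 nM, all in a functional assay on BE(2)-C cells (Homo sapiens) for inhibition, read by MTT assay, with a stated time of 72 h; a lower number here means a stronger inhibitor of growth, a higher number a weaker inhibitor of growth.

Compound 3 stands second highest of the three numbers. Its nearest neighbour is compound 2, a gap within the scatter a 1.3-fold higher number from compound 2 to compound 3 (0.12 log units; within the scatter); its furthest is compound 1 a 5.2-fold lower number from compound 1 to compound 3 (0.71 log units; beyond the scatter). Compound 4 `O=S(=O)(NCCCNCc1ccc(Cl)c(C(F)(F)F)c1)c1cc(C(F)(F)F)cc(C(F)(F)F)c1` carries trifluoromethyl in place of chloro on an aromatic carbon. For the measured compounds named here, no measured step swaps these two groups; the steps that touch the benzyl ring, a 5.2-fold lower number from compound 1 to compound 3 (0.71 log units; beyond the scatter) and a 6.8-fold lower number from compound 1 to compound 2 (0.83 log units; beyond the scatter), show that the halogen pattern there matters, while the 3,4-dichlorophenyl and 4-bromophenyl variants sit close. Compound 4 is therefore expected to move little, perhaps slightly lower a 1.5-fold lower number from compound 3 to compound 4 (0.16 log units; within the scatter). For compound 4 the estimate is 2000 nM, between 700 nM and 6000 nM.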

Compound 4, concentration for 50% growth inhibition: 8600 nM
Compound 4: the middle estimate sits 4.3-fold (0.63 log units) below what was measured, outside the stated range (above it).
By their numbers in this assay, from the lowest: compounds 2 and 3 (each within the scatter of the next); then compounds 4 and 1 (each within the scatter of the next).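

In this assay this position on the benzyl ring, ortho to a chloro group, proves sensitive to the swap: trifluoromethyl in place of chloro gives a 3.0-fold higher number from compound 3 to compound 4 (0.47 log units; beyond the scatter) and so weakens growth inhibition. The 4-chloro-3-(trifluoromethyl)phenyl group also gives up the clear advantage that 3,4-dichlorophenyl held over 2-chlorophenyl, with a 1.7-fold lower number from compound 1 to compound 4 (0.24 log units; within the scatter). No measurement here accounts for this shift.

As far as these compounds go, whether a methyl or nitrile group at this position would match chloro remains open. So does whether a longer chain would alter the outcome with this ring.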